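Cytotoxicity of a diaryl-methyl pyrimidinone series

This account rests on a few compounds, and the source may have more. Where it says the series, first, only, none or still open, it means among the compounds named here.

Measured compounds:
Compound 1 `Cc1c(Cc2c(F)cccc2F)nc(N2CCCC2)[nH]c1=O` gives in an ADME assay on MT4 cells (Homo sapiens) for cytotoxicity, read by MTT assay, with a stated time of 4 days (on this read-out lower numbers stand for higher toxicity in this test and higher numbers for lower toxicity in this test), a limit of > 82000 nM.
Compound 2 `Cc1c(Cc2c(F)cccc2F)nc(N2CCCCC2)[nH]c1=O` gives a limit of > 78000 nM.
Compound 3 `Cc1c(C(C)c2c(F)cccc2F)nc(N2CCCC2)[nH]c1=O` gives a limit of > 78000 nM.

All three values are limits of the assay, not numbers. Two of them sit at the limit of > 78000 nM in this assay, at which 2 of the 3 values shown sit, and one at the limit of > 82000 nM in this assay, at which 1 of the 3 values shown sits. The change piperidin-1-yl in place of pyrrolidin-1-yl on an aromatic carbon gives a step that the two limits leave unreadable from compound 1 to compound 2. The change methyl in place of hydrogen on a saturated chain carbon bound to two aromatic carbons gives a step that the two limits leave unreadable from compound 1 to compound 3.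

Compound 4 `Cc1c(C(C)c2c(F)cccc2F)nc(N2CCCCC2)[nH]c1=O` is not yet measured. It differs from compound 3 by piperidin-1-yl in place of pyrrolidin-1-yl on an aromatic carbon, the same kind of change as from compound 1 to compound 2, though around the place the surroundings read "meta to a large group" rather than "meta to a group of 9 heavy atoms". Since the shared change gave a step that the two limits leave unreadable from compound 1 to compound 2, the step that the limit leaves unreadable from compound 3 to compound 4 is expected to be unreadable as well. Compound 4 is expected to give 100000 nM, most likely again a limit.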

Compound 4, half-maximal cytotoxic concentration: > 75000 nM
Compound 4 was reported as a limit; the forecaster's own chance of this, stated with the estimate: 90%; the middle value is on the limit's open side.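

Compound 4 gives > 75000 nM, again a limit of the assay and not a number. Its steps from compound 2 and from compound 3 cannot be read. The compounds shown leave open at what concentration any of them becomes cytotoxic in this assay.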